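Amide Substituent Swap on a Shared Core: Expected Cytotoxicity

A few compounds are considered here, and "the series" means these few. Any claim that something is new, unique, unknown or untested is made for them only; others in the source may bear on it.

Compound 2 `C=CC1=C(C(=O)NCc2ccccc2F)C(c2ccc(OC)cc2)OC1` was tested in a functional assay on HeLa cells (Homo sapiens) for cytotoxicity, read by MTT assay, with a stated time of 24 h; a lower number here means a stronger inhibitor, a higher number a weaker inhibitor. In this assay compound 2 gives only a limit, > 100000 nM, so no exact number is known for it. Compound 1 `C=CC1=C(C(=O)NCc2ccc(Cl)cc2)C(c2ccc(OC)cc2)OC1` likewise gives only a limit in this assay, namely > 100000 nM. The step from the first to the second compound is a step that the two limits leave unreadable from compound 1 to compound 2, so it teaches nothing about size or direction. Compound 3 `C=CC1=C(C(=O)Nc2ccc(C)cc2)C(c2ccc(OC)cc2)OC1` differs from compound 2 in a single place: 4-methylphenyl in place of 2-fluorobenzyl on an amide-type nitrogen. Among the compounds with values here, no measured step covers a change of this kind. What remains to go on is the limit of > 100000 nM in this assay, at which 2 of the 2 values shown sit, which shows both measured compounds resting at the limit rather than at a number. Compound 3 is therefore expected to sit near that limit as well, with an estimated step that the limit leaves unreadable from compound 2 to compound 3. The estimate for compound 3 in this assay is 200000 nM, with a range from 50000 nM to 1000000 nM, and the assay is expected most likely to report only a limit again.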

Compound 3, half-maximal inhibitory concentration: > 100000 nM
Compound 3 gave a limit, no number; the forecaster's own chance of this, stated with the estimate: 75%; the middle value lies beyond the limit too.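

In this assay compound 3 gives only a limit, > 100000 nM, so its steps from compound 1 and from compound 2 cannot be read. The compounds shown leave open whether any change on the amide-type nitrogen alters cytotoxicity at all: the limit of > 100000 nM in this assay, at which 3 of the 3 values shown sit.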